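This account rests on a few compounds, and the source may have more. Where it says the series, first, only, none or still open, it means among the compounds named here.

Of the compounds shown here, three that share one core have been measured in an assay on isolated protein for inhibition of high affinity 3',5'-cyclic-AMP phosphodiesterase 7A (Homo sapiens), read by cAMP accumulation, with a stated time of 20 min; a lower number here means a stronger inhibitor, a higher number a weaker inhibitor. Compound 1 `CCCCCn1c(-c2ccccc2)nc2c(N)ccnc21` gives a value that is only a limit of the assay, > 200000 nM. Compound 2 `CCCCCn1c(-c2ccc([N+](=O)[O-])cc2)nc2c(N)ccnc21` likewise gives only a limit, > 200000 nM. Compound 3 `CCCCCn1c(-c2ccco2)nc2c(N)ccnc21` also gives only a limit, > 200000 nM. Because every value sits at the limit of > 200000 nM in this assay, at which 3 of the 3 values shown sit, the two steps that can be drawn, a step that the two limits leave unreadable from compound 1 to compound 2 and a step that the two limits leave unreadable from compound 1 to compound 3, cannot be sized. Compound 4 `CCCCCn1c(-c2ccco2)nc2c(NCCOC)ccnc21` is not yet measured; it differs from compound 3 by 2-methoxyethyl in place of hydrogen on a nitrogen on an aromatic ring. Within the data shown here, none of the measured steps touches this nitrogen, so no measured step bears on the change, and the three known values leave this assay without a single readable number. The expectation for compound 4 therefore rests only on where compound 3 stands. The step expected in this assay is an at least 1.3-fold lower number from compound 3 to compound 4 (0.12 log units; that floor lies within the scatter). Compound 4 is estimated at 150000 nM in this assay, with a range from 30000 nM to 300000 nM, and most likely the assay again reports only a limit.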

Compound 4, half-maximal inhibitory concentration: > 200000 nM
Compound 4: no number, only a limit; the forecaster's own chance of this, stated with the estimate: 70%; middle value at least 1.3-fold (0.12 log units) from the limit.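

In this assay compound 4 gives > 200000 nM as a limit of the assay, not a number. The step from compound 3 to compound 4 cannot be read, because both values sit at the same limit: the limit of > 200000 nM in this assay, at which 4 of the 4 values shown sit. The compounds shown leave open how strongly any of them inhibits the enzyme, and which change to the shared core would give a readable number.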